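Swapping One Side Chain on Compound 1

A few compounds are considered here, and "the series" means these few. Any claim that something is new, unique, unknown or untested is made for them only; others in the source may bear on it.

In a functional assay on HCT-116 cells (Homo sapiens) for inhibition, read by MTT assay, with a stated time of 72 h (on this read-out higher numbers stand for weaker inhibition of growth and lower numbers for stronger inhibition of growth), compound 1 `CCOC(=O)/C=C/c1ccncc1-c1ccc2ccccc2c1` gives 910 nM. Within the data shown here, this is the only number available, so it cannot yet be ranked as strong or weak against close relatives. The result for compound 2 `O=C(O)CCNC(=O)/C=C/c1ccncc1-c1ccc2ccccc2c1` stands as "not determined" (no result reported). The result for compound 3 `CC(C)[C@@H](NC(=O)/C=C/c1ccncc1-c1ccc2ccccc2c1)C(=O)O` stands as "not determined" (no result reported). Compound 4 `O=C(O)CCc1ccncc1-c1ccc2ccccc2c1` keeps the shared core but carries 2-carboxyethyl in place of 2-(ethoxycarbonyl)ethenyl on an aromatic carbon. Among the measured compounds shown here, no measured pair shows what such a swap does, so any forecast is tentative. A clear move toward weaker inhibition of growth, meaning a higher number in this assay, is expected, with an estimated size of a 6.6-fold higher number from compound 1 to compound 4 (0.82 log units; beyond the scatter). Compound 4 is expected to give about 6000 nM, within an estimated range of 1500 nM to 30000 nM.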

Compound 4, concentration for 50% growth inhibition: > 30000 nM
Compound 4: only a limit was reported; the forecaster's own chance of this, stated with the estimate: 25%; at least 5.0-fold (0.69 log units) between middle value and limit.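

On an aromatic carbon opposite the ring nitrogen, putting 2-carboxyethyl in place of 2-(ethoxycarbonyl)ethenyl gives an at least 32-fold higher number from compound 1 to compound 4 (1.51 log units; beyond the scatter) in this assay, meaning much weaker inhibition of growth. This first readable step shows that activity at this position depends strongly on the side chain. Compound 4 reached only a limit of the assay, so the true size of the step stays unknown: the limit of > 30000 nM in this assay, at which 1 of the 4 values shown sits.

This swap removes the ester and the chain's carbon-carbon double bond together, so the compounds shown cannot separate the two changes. A 2-carboxyethenyl group or a 2-(ethoxycarbonyl)ethyl group would change only one of them.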